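This account rests on a few compounds, and the source may have more. Where it says the series, first, only, none or still open, it means among the compounds named here.

In a functional assay on MDA-MB-231 cells (Homo sapiens) for antiproliferative activity, read by MTT assay, with a stated time of 48 h (a lower number here means a stronger inhibitor, a higher number a weaker inhibitor), compound 1 (`C=CS(=O)(=O)N1CCN(c2ncnc3sc(-c4ccc(OC)cc4)cc23)CC1`) gives 29900 nM and compound 2 (`C=CS(=O)(=O)N1CCN(c2ncnc3sc(-c4ccc(N5CCN(C)CC5)cc4)cc23)CC1`) gives 7550 nM as the lower of the two numbers, a modest step (a 4.0-fold lower number from compound 1 to compound 2 (0.60 log units; beyond the scatter)). Compound 3 (`CN1CCN(c2ccc(-c3cc4c(N5CCN(S(=O)(=O)N6CCCCC6)CC5)ncnc4s3)cc2)CC1`) differs from compound 2 on a sulfonyl sulfur, with piperidin-1-yl in place of vinyl (piperidin-1-yl in place of vinyl on a sulfonyl sulfur). For the measured compounds named here, the only measured step changes a group on an aromatic carbon, not on the sulfonyl sulfur, so it gives no size for this change, and no step beyond the scatter is expected. The estimated step (a 1.2-fold higher number from compound 2 to compound 3 (0.08 log units; within the scatter)) is therefore small, though uncertain. Compound 3 is expected at 9000 nM (2500 nM to 30000 nM).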

Compound 3, half-maximal inhibitory concentration: 8130 nM
Compound 3: middle estimate off by 1.1-fold (0.04 log units), on the high side; low and high end bracket the measured number.
By their numbers in this assay, from the lowest: compounds 2 and 3 (each within the scatter of the next); then compound 1.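

In this assay, replacing vinyl with piperidin-1-yl on the sulfonyl sulfur gives a step within the scatter (a 1.1-fold higher number from compound 2 to compound 3 (0.03 log units; within the scatter)). For the compounds shown here, the earlier pair changed only a group on an aromatic carbon, so this is the first reading at the sulfonyl sulfur: here, a six-membered non-aromatic ring in place of the vinyl double bond leaves the two compounds indistinguishable. No evidence given here accounts for this result. Still open, on these data alone, is how a morpholine, a dimethylamino group or a methyl group on the sulfonyl sulfur would read, and whether piperidin-1-yl there would read the same alongside methoxy on the aromatic carbon.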